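The compounds below may be only part of what the source reports. "The series", "measured", "known", "first", "only" and "open" are said of these compounds alone.

In an assay on microsomes from liver for inhibition of 3-hydroxy-3-methylglutaryl-coenzyme A reductase (Rattus norvegicus) (a lower number here means a stronger inhibitor, a higher number a weaker inhibitor), two compounds on the shared core have been measured. Compound 1 `CC(C)c1c(C(=O)NCc2ccccc2Cl)nn(-c2ccc(F)cc2)c1OC[C@@H](O)C[C@@H](O)CC(=O)O` gives 9.5 nM. Compound 2 `COc1cc(CN(C)C(=O)c2nn(-c3ccc(F)cc3)c(OC[C@@H](O)C[C@@H](O)CC(=O)O)c2C(C)C)cc(OC)c1` gives 43 nM, the higher of the two numbers, and the gap between compound 1 and compound 2 lies beyond the usual scatter; since the two structures differ in more than one place, no single step can be read from them. Compound 3 `CC(C)c1c(C(=O)N(C)Cc2cccc(F)c2)nn(-c2ccc(F)cc2)c1OC[C@@H](O)C[C@@H](O)CC(=O)O` has not yet been measured. It arises from compound 2 by one change: 3-fluorophenyl in place of 3,5-dimethoxyphenyl on a saturated chain carbon bound to an amide-type nitrogen. The methyl on the amide nitrogen and the rest of the molecule stay as they are. For the measured compounds named here, no measured pair shows this change on its own, so the size of the step in this assay can only be guessed. Compound 1 also carries a halogen-bearing benzyl on the amide and gives the lower number 9.5 nM, which hints that a halogenated benzyl goes together with a low number in this assay. Compound 3 is therefore expected to come in lower than compound 2, estimated at 20 nM, within 6 nM to 70 nM. The expected step of a 2.2-fold lower number from compound 2 to compound 3 (0.33 log units; beyond the scatter) is toward a lower number, though it may not clear the scatter.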

Compound 3, half-maximal inhibitory concentration: 14 nM
Compound 3: the middle estimate sits 1.4-fold (0.15 log units) above what was measured; the range from low to high includes it.
By their numbers in this assay, from the lowest: compounds 1 and 3 (each within the scatter of the next); then compound 2.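

In this assay, the benzyl group on the amide now has a step that can be read on its own: 3-fluorophenyl in place of 3,5-dimethoxyphenyl, on a saturated chain carbon bound to an amide-type nitrogen, gives a 3.1-fold lower number from compound 2 to compound 3 (0.49 log units; beyond the scatter) with the methyl on the amide nitrogen held fixed. The comparison of (3-fluorobenzyl)(methyl)amino with (2-chlorobenzyl)amino on a carbonyl carbon gives a 1.5-fold higher number from compound 1 to compound 3 (0.17 log units; within the scatter), so an amide nitrogen with a methyl and one without it both occur in the same range here, although the halogen and the benzyl pattern change in that same step. Nothing measured here offers an explanation for either step.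

An unsubstituted benzyl or a 3-methoxybenzyl on the same methylated amide would show whether the lower number of compound 3 follows the fluorine or the departure of the two methoxy groups. A 2-chlorobenzyl on the methylated amide would separate the effect of the methyl from that of the benzyl pattern, which compound 1 and compound 3 leave entangled.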